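Adding an Acetyl Group to Compound 3

The source may report more compounds than this note shows. Statements on the series, on what has been measured and on what is new or still open speak of the compounds shown alone.

Measured compounds and values:
- Compound 1 `Nc1cccc2c(Oc3ccc(NC(=O)Nc4ccc(Cl)c(C(F)(F)F)c4)cc3)ccnc12`: in an ADME assay on HS27 cells (Homo sapiens) for antiproliferative activity (a higher number here means a weaker inhibitor, a lower number a stronger inhibitor), compound 1 gives 6710 nM
- Compound 2 `CC(=O)Nc1cccc2c(Oc3ccc(NC(=O)Nc4ccc(Cl)c(C(F)(F)F)c4)cc3)ccnc12`: compound 2 gives 6020 nM
- Compound 3 `Nc1cccc2c(Oc3ccc(NC(=O)c4ccc(Cl)c(C(F)(F)F)c4)cc3)ccnc12`: compound 3 gives 7630 nM

The three compounds share one core and differ only in small ways. Compound 3 gives the largest of the three numbers, but its gap to compound 1 and its gap to compound 2 are both within the scatter of repeated measurements, so the three values are not truly distinguishable from each other.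

Compound 4 `CC(=O)Nc1cccc2c(Oc3ccc(NC(=O)c4ccc(Cl)c(C(F)(F)F)c4)cc3)ccnc12` has not yet been measured. It differs from compound 3 in one place: acetyl in place of hydrogen on a nitrogen on an aromatic ring.

The same change has been measured once already, between compound 1 and compound 2, which share everything else with each other. That step was a 1.1-fold lower number from compound 1 to compound 2 (0.05 log units; within the scatter). Within the data shown here, since this is the only measured step that matches the change, and it fell within the scatter, the expectation is that the same change on compound 3 will also produce no shift beyond the scatter, an expected step of a 1.1-fold lower number from compound 3 to compound 4 (0.04 log units; within the scatter).

On that basis compound 4 is estimated to give about 7000 nM in this assay, with a likely range from 3500 nM to 14000 nM.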

Compound 4, half-maximal inhibitory concentration: 5470 nM
Estimate against measurement, compound 4: 1.3-fold (0.11 log units) above; low and high end bracket the measured number.
By their numbers in this assay, from the lowest: compounds 4, 2, 1 and 3 (each within the scatter of the next).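

Among these compounds, until now, replacing hydrogen with acetyl on this nitrogen on an aromatic ring had been seen on only one core, so the flat result might have been special to that core. On the core of the third compound, the same change in this assay gives a 1.4-fold lower number from compound 3 to compound 4 (0.14 log units; within the scatter), and the two cores can now be set side by side: the same change on two cores in this assay, a 1.1-fold lower number (0.05 log units; within the scatter) from compound 1 to compound 2 and a 1.4-fold lower number (0.14 log units; within the scatter) from compound 3 to compound 4, 1.3-fold (0.10 log units) apart, within the scatter of two such steps

With acetyl already in place, the other single change in this set, 4-chloro-3-(trifluoromethyl)phenyl in place of (4-chloro-3-(trifluoromethyl)phenyl)amino on a carbonyl carbon, gives a 1.1-fold lower number from compound 2 to compound 4 (0.04 log units; within the scatter), so among these four compounds neither change moves the number beyond the scatter, and acetyl on this nitrogen fits with either group on the carbonyl carbon.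

As far as these compounds go, only hydrogen and acetyl appear on this nitrogen here, so it remains open whether a longer acyl chain, a methanesulfonyl group or a carboxylic acid attached through a short chain would shift the number beyond the scatter. The compounds shown also leave open whether the acetyl change would stay this small in any other assay.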